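Acylated amine tails: from piperidine urea to oxalamide

The source may hold more compounds than are shown below. What is called first, only, known or untested is meant among the compounds shown, and "the series" means these compounds.

Measured compounds:
Compound 1 `COc1ccc(/C(=C(/CCN)c2ccccc2)c2ccccc2)cc1` — 16900 nM
Compound 2 `CCN(CC)C(=O)NCC/C(=C(\c1ccccc1)c1ccc(OC)cc1)c1ccccc1` — > 50000 nM
Compound 3 `COc1ccc(/C(=C(/CCNC(=O)N2CCCCC2)c2ccccc2)c2ccccc2)cc1` — > 50000 nM

Three compounds share the same core and differ only at the amine nitrogen of the side chain. In a functional assay on MCF7 cells (Homo sapiens) for cytotoxicity, read by MTT assay, with a stated time of 72 h (on this read-out higher numbers stand for weaker inhibition and lower numbers for stronger inhibition), compound 1, with a free amine, gives 16900 nM. For compound 2 the result is a limit of the assay, > 50000 nM. For compound 3 the result is likewise a limit, > 50000 nM. Compound 3 therefore stands at the weak end of what was seen, sharing that position with compound 2, as the limit of > 50000 nM in this assay, at which 2 of the 3 values shown sit, shows.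

Compound 4 `COc1ccc(/C(=C(/CCNC(=O)C(=O)NCc2ccccc2)c2ccccc2)c2ccccc2)cc1` keeps the acylated nitrogen but changes the group on the carbonyl: benzylcarbamoyl in place of piperidin-1-yl on a carbonyl carbon.

Going by the values given here, two measured steps bear on this. Capping the amine gave an at least 2.9-fold higher number from compound 1 to compound 2 (0.47 log units; beyond the scatter) and an at least 2.9-fold higher number from compound 1 to compound 3 (0.47 log units; beyond the scatter). Between the two capped compounds, a step that the two limits leave unreadable from compound 2 to compound 3. Both capping groups sit at the limit, so the data say only that acylation of the nitrogen weakens inhibition; they do not separate one capping group from another.

Since compound 4 is also acylated at that nitrogen, it is expected to stay weak, with a step that the limit leaves unreadable from compound 3 to compound 4. The estimate for compound 4 is 60000 nM, from 20000 nM to 200000 nM, most likely reported again as a limit.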

Compound 4, half-maximal inhibitory concentration: > 50000 nM
Compound 4: a limit, no number (the forecaster's own chance of this, stated with the estimate: 65%); the middle value is on the limit's open side.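

In this assay compound 4 gives another limit of the assay, > 50000 nM, and not a number. The change to (benzylcarbamoyl)carbonyl on the amine nitrogen gives an at least 2.9-fold higher number from compound 1 to compound 4 (0.47 log units; beyond the scatter), so a capping group with an aromatic ring and a hydrogen-bond donor on its far side ends up in the same place as the piperidine and diethylamino ureas. The steps among the capped compounds cannot be read, so even this larger change of the group on the carbonyl carbon does not separate compound 2, compound 3 and compound 4, and compound 1 remains the only compound here with a measured number: the limit of > 50000 nM in this assay, at which 3 of the 4 values shown sit.

The compounds shown leave open whether any substituent on this nitrogen can keep a number within range, for example a single methyl or two methyl groups, which would leave the nitrogen an amine instead of turning it into an amide or urea. They also leave open how a longer chain between the shared core and the free amine would read, since the chain length is the same in all the compounds shown.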